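Nitro in place of methoxy: what compound 3 may show

This account rests on a few compounds, and the source may have more. Where it says the series, first, only, none or still open, it means among the compounds named here.

Measured in a functional assay on B16-F10 cells (Mus musculus) for antiproliferative activity, read by MTT assay, with a stated time of 48 h; a lower number here means a stronger inhibitor, a higher number a weaker inhibitor:
- compound 1 `O=C(/C=C/c1ccc(O)c(O)c1)N1CCN(c2ccccc2F)CC1`: 2.43 ug/mL
- compound 2 `COc1ccc(N2CCN(C(=O)/C=C/c3ccc(O)c(O)c3)CC2)cc1`: 1.21 ug/mL

Going by the values given here, only two compounds have numbers so far, and compound 2 stands within the scatter of compound 1, so the two cannot be ranked. The next compound, compound 3 `O=C(/C=C/c1ccc(O)c(O)c1)N1CCN(c2ccc([N+](=O)[O-])cc2)CC1`, keeps the core of compound 2 and alters one group: nitro in place of methoxy on an aromatic carbon.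

Among the compounds with values here, one measured step bears on this: a 2.0-fold lower number from compound 1 to compound 2 (0.30 log units; within the scatter). It exchanges a 2-fluorophenyl for a 4-methoxyphenyl and stays within the scatter. Within the data shown here, no measured compound carries nitro, so the data give no direct reading of this group. Among the measured compounds shown here, with that single small step as the only guide, no change beyond the scatter is expected in this assay, and no direction can be argued with any confidence.

The estimated change is a 1.5-fold higher number from compound 2 to compound 3 (0.17 log units; within the scatter). The expected value for compound 3 is 1.8 ug/mL, with an estimated range from 0.7 ug/mL to 4.5 ug/mL.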

Compound 3, half-maximal inhibitory concentration: 1.79 ug/mL
For compound 3 the middle estimate is 1.0-fold (0.00 log units) above the measured one, within the range that was stated.
By their numbers in this assay, from the lowest: compounds 2, 3 and 1 (each within the scatter of the next).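

In this assay, the exchange of methoxy for nitro on an aromatic carbon, para to a large group, gives a 1.5-fold higher number from compound 2 to compound 3 (0.17 log units; within the scatter) and so adds a second step at this site that stays within the scatter. Set against the 2-fluorophenyl group, the 4-nitrophenyl group gives a 1.4-fold lower number from compound 1 to compound 3 (0.13 log units; within the scatter), which means that the three aryl groups shown cannot be ranked in this assay, even though nitro brings nitrogen and a double bond outside aromatic rings that methoxy lacks. The position therefore accepts these three substituent patterns without a change beyond the scatter, but no accompanying measurement indicates why they read alike.

The three compounds leave open whether a clearly different group on the same aromatic carbon, such as an amine or a carboxylic acid, would move the number beyond the scatter. They also leave open how much the shared core contributes, since every compound shown keeps it unchanged and none replaces its hydroxyl groups with methoxy groups or extends its chain.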